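Trading bromo for allyl on an inactive-looking compound

The compounds below may be only part of what the source reports. "The series", "measured", "known", "first", "only" and "open" are said of these compounds alone.

In a functional assay on BV-2 cells (Mus musculus) for inhibition, read by Griess assay, with a stated time of 24 h (a higher number here means a weaker inhibitor, a lower number a stronger inhibitor), compound 3 `Oc1ccc(Br)cc1-c1ccn(-c2ccccc2)n1` gives > 200000 nM, which is a limit of the assay and not a number. This places compound 3 at the limit of > 200000 nM in this assay, at which 1 of the 3 values shown sits.

Two related compounds do give numbers. Compound 1 `C=CCOCc1cc(-c2cc(Br)ccc2OC)no1` reads 90400 nM and compound 2 `C=CCn1ccc(-c2cc(Br)ccc2O)n1` reads 112000 nM, and these two values lie within the scatter of each other.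

Compound 4 `C=CCc1ccc(O)c(-c2ccn(-c3ccccc3)n2)c1` keeps the core of compound 3 and has allyl in place of bromo on an aromatic carbon.

For the measured compounds named here, only one measured step involves compound 3: an at least 1.7-fold higher number from compound 2 to compound 3 (0.25 log units; that floor lies within the scatter). Going by the values given here, that step puts phenyl in place of allyl on an aromatic nitrogen, which is a different place from the one that changes here, so it gives only weak guidance. Among the compounds with values here, no measured pair shows the swap of bromo for allyl directly.

A modest move to a lower number in this assay is still expected because allyl-bearing compound 2 gives 112000 nM. The estimated change is an at least 2.8-fold lower number from compound 3 to compound 4 (0.45 log units; beyond the scatter). For compound 4 the estimate is 70000 nM, with an expected range from 20000 nM to 200000 nM.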

Compound 4, half-maximal inhibitory concentration: 73000 nM
Compound 4: middle estimate off by 1.0-fold (0.02 log units), on the low side; the range from low to high includes it.
By their numbers in this assay, from the lowest: compounds 4, 1 and 2 (each within the scatter of the next). At a limit, above all of these: compound 3.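

In this assay, allyl in place of bromo on an aromatic carbon, para to a hydroxy group, gives an at least 2.7-fold lower number from compound 3 to compound 4 (0.43 log units; beyond the scatter). For the compounds shown here, the only earlier step, an at least 1.7-fold higher number from compound 2 to compound 3 (0.25 log units; that floor lies within the scatter), changed the group on an aromatic nitrogen, so this is the first reading of a change on this carbon, and it turns a compound without a measured number into one with a number. Compound 3 gives > 200000 nM, which is a limit of the assay and not a number, so the step is only a floor and the real gap may be wider: the limit of > 200000 nM in this assay, at which 1 of the 4 values shown sits.

With only bromo and allyl seen at this position, the compounds shown cannot separate the gain from adding allyl from the gain from losing bromo, and a plain hydrogen, a propyl chain or an amine in that place would help to tell these apart. As far as these compounds go, whether the same swap gives a similar step on a core with allyl on the aromatic nitrogen, as in compound 2, also stays open.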